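The source may hold more compounds than are shown below. What is called first, only, known or untested is meant among the compounds shown, and "the series" means these compounds.

Within the data shown here, compound 2 `c1ccc(C(/N=C2\CCCCCN2)C2CCCC2)cc1` is one of two compounds measured in a functional assay on the whole organism (plasma, strain Sprague-Dawley) with Rattus norvegicus as the target, with a stated time of 2 h, at a dose of 100 mg/kg by the oral route (a higher number here means a stronger effect of the compound at the dose given, a lower number a weaker effect), where compound 2 gives 46%. Among the measured compounds shown here, the other, compound 1 `c1ccc(C(/N=C2\CCCCCN2)C2CCC2)cc1`, gives 44% in this assay, and the single measured step between them is a number 2 percentage points higher from compound 1 to compound 2 (within the scatter), so the two numbers sit within the scatter of each other. Compound 3 `c1ccc(C(/N=C2\CCCCCN2)C2CCCCCC2)cc1` has not yet been measured in this assay. It differs from compound 2 in one place: cycloheptyl in place of cyclopentyl on a saturated chain carbon bound to an aromatic carbon and a double-bonded nitrogen. For the measured compounds named here, the only measured step that bears on this change is a number 2 percentage points higher from compound 1 to compound 2 (within the scatter), where a larger ring at the same place left the read-out unchanged beyond the scatter. The move to cycloheptyl goes further than any measured pair covers, so the expectation rests on that single flat step alone. For compound 3 the expected step in this assay is a number 1 percentage points lower from compound 2 to compound 3 (within the scatter). Compound 3 is therefore estimated at 45%, with a range from 25% to 65%.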

Compound 3, a percentage reported as inhibition, in the whole organism at one dose (the size of the read-out at that dose, not a potency): 6%
Beside the measured number, compound 3's estimate is 39 percentage points above it, and the stated range ends above it.
By their numbers in this assay, from the lowest: compound 3; then compounds 1 and 2 (each within the scatter of the next).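

In this assay, the ring on this saturated chain carbon turns out not to be freely interchangeable: cycloheptyl costs a large part of the read-out, with a number 40 percentage points lower from compound 2 to compound 3 (beyond the scatter) and a number 38 percentage points lower from compound 1 to compound 3 (beyond the scatter). The flat step between the cyclobutyl and cyclopentyl compounds had shown no sensitivity to ring size, so across these three compounds the response to ring size is not even, and the loss appears only with the seven-membered ring. Nothing in the available data explains this loss.

The compounds shown leave open whether cyclohexyl would keep the read-out of the smaller rings or already share the loss seen with cycloheptyl, which would place the point of the drop. They also leave open how an open-chain group such as isopropyl or an aromatic phenyl would fare at this carbon.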